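Swapping chloro for nitro on an antiproliferative compound

The compounds below may be only part of what the source reports. "The series", "measured", "known", "first", "only" and "open" are said of these compounds alone.

Results so far in a functional assay on A549 cells (Homo sapiens) for antiproliferative activity, read by MTT assay, with a stated time of 72 h (a higher number here means a weaker inhibitor, a lower number a stronger inhibitor), for three compounds
Compound 1 `COc1cc(CCc2ccccc2)cc(OC)c1O` gives 10900 nM
Compound 2 `COc1cc(CCc2ccc(F)cc2)cc(OC)c1O` gives 4150 nM
Compound 3 `COc1cc(CCc2ccc(Cl)cc2)cc(OC)c1O` gives 22900 nM

Compound 3 has the highest number of the three and is the weakest inhibitor among them, since its steps to both others lie beyond the scatter. Compound 4 `COc1cc(CCc2ccc([N+](=O)[O-])cc2)cc(OC)c1O` has nitro in place of chloro on an aromatic carbon, para to a large group (nitro in place of chloro on an aromatic carbon). Going by the values given here, no nitro compound has been measured yet, so the closest guides are three steps at this same place: fluoro in place of hydrogen (a 2.6-fold lower number from compound 1 to compound 2 (0.42 log units; beyond the scatter)), chloro in place of hydrogen (a 2.1-fold higher number from compound 1 to compound 3 (0.32 log units; beyond the scatter)) and chloro in place of fluoro (a 5.5-fold higher number from compound 2 to compound 3 (0.74 log units; beyond the scatter)). All three are modest and they run in both directions, so none of them predicts nitro directly. With compound 3 at the top of the range at 22900 nM in this assay, a modest move to a lower number is the expected outcome. The estimate amounts to a step (a 2.3-fold lower number from compound 3 to compound 4 (0.36 log units; beyond the scatter)). Compound 4 is estimated at 10000 nM (expected range 3000 nM to 30000 nM).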

Compound 4, half-maximal inhibitory concentration: 9130 nM
Beside the measured number, compound 4's estimate is 1.1-fold (0.04 log units) above it; the range from low to high includes it.
By their numbers in this assay, from the lowest: compound 2; then compounds 4 and 1 (each within the scatter of the next); then compound 3.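

In this assay, a 2.5-fold lower number from compound 3 to compound 4 (0.40 log units; beyond the scatter) shows that this aromatic carbon can hold nitro, which has more heavy atoms than chloro and hydrogen-bond acceptors that chloro lacks, without any loss of activity. Beside the compound with hydrogen at this place, the change is a 1.2-fold lower number from compound 1 to compound 4 (0.08 log units; within the scatter) and so makes no clear difference, while a 2.2-fold higher number from compound 2 to compound 4 (0.34 log units; beyond the scatter) shows that nitro does not match fluoro here. The numbers therefore do not follow the heavy-atom count of the group, since chloro, and not the larger nitro, gives the highest number of the four.

Nothing available explains why these groups differ. Still open, from the compounds shown here alone, is how an amine or a carboxylic acid would behave at this place on the shared core, and whether either would reach a lower number than fluoro.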